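The source may hold more compounds than are shown below. What is called first, only, known or untested is meant among the compounds shown, and "the series" means these compounds.

Compound 1 `CC(C)NC(=S)N/N=C1\CC(c2ccc(O)cc2)Oc2cc(O)ccc21` carries an isopropylamino group on a thiocarbonyl carbon of the shared core. In a functional assay on SGC-7901 cells (Homo sapiens) for cytotoxicity, read by MTT assay, with a stated time of 72 h (on this read-out lower numbers stand for stronger inhibition and higher numbers for weaker inhibition), compound 1 gives 35200 nM, the lowest of the three numbers recorded, although both companions sit within the scatter of it. Compound 2 `Oc1ccc(C2C/C(=N\NC(=S)N3CCCCC3)c3ccc(O)cc3O2)cc1` gives 40000 nM in this assay, and compound 3 `Oc1ccc(C2C/C(=N\NC(=S)N3CCOCC3)c3ccc(O)cc3O2)cc1` gives 52200 nM. The steps between them are small: a 1.1-fold higher number from compound 1 to compound 2 (0.06 log units; within the scatter), a 1.5-fold higher number from compound 1 to compound 3 (0.17 log units; within the scatter) and a 1.3-fold higher number from compound 2 to compound 3 (0.12 log units; within the scatter), each within the scatter, so exchanging the group on a thiocarbonyl carbon has so far moved the number little.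

Compound 4 `CC(C)(C)NC(=S)N/N=C1\CC(c2ccc(O)cc2)Oc2cc(O)ccc21` differs from compound 1 by methyl in place of hydrogen on a saturated chain carbon bound to an amide-type nitrogen and two saturated chain carbons. The three measured steps all touch the same part of the molecule and all lie within the scatter, so for compound 4 in this assay no step beyond the scatter is expected, in either direction. Compound 4 is therefore expected to give 38000 nM, with a range from 18000 nM to 80000 nM, which corresponds to an expected step of a 1.1-fold higher number from compound 1 to compound 4 (0.03 log units; within the scatter).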

Compound 4, half-maximal inhibitory concentration: 31000 nM
Beside the measured number, compound 4's estimate is 1.2-fold (0.09 log units) above it; the range from low to high includes it.
By their numbers in this assay, from the lowest: compounds 4, 1, 2 and 3 (each within the scatter of the next).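

Methyl in place of hydrogen on the saturated chain carbon bound to an amide-type nitrogen and two saturated chain carbons turns isopropylamino into (tert-butyl)amino, and in this assay this open-chain change stays within the scatter (a 1.1-fold lower number from compound 1 to compound 4 (0.06 log units; within the scatter)). Against the two ring-bearing groups on the thiocarbonyl carbon, (tert-butyl)amino also stays within the scatter (a 1.3-fold lower number from compound 2 to compound 4 (0.11 log units; within the scatter); a 1.7-fold lower number from compound 3 to compound 4 (0.23 log units; within the scatter)), so the extra carbon does not set compound 4 apart from the other three compounds. Nothing at hand explains this flat picture.

From the compounds shown here alone, it remains open whether a phenylamino group or a longer chain such as hexylamino on the thiocarbonyl carbon would move the number beyond the scatter. The same question stands for methoxy in place of the hydroxyl groups on the shared core.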